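The compounds below may be only part of what the source reports. "The series", "measured", "known", "first", "only" and "open" are said of these compounds alone.

Measured compounds in a functional assay on SF-295 cells (Homo sapiens) for cytotoxicity, read by sulforhodamine B assay, with a stated time of 48 h; a lower number here means a stronger inhibitor of growth, a higher number a weaker inhibitor of growth:

compound 1, `ClCc1cccc(Cn2cnc3c(Cl)ncnc32)c1`: 8700 nM
compound 2, `ClCc1cccc(Cn2cnc3c(Cl)nc(Cl)nc32)c1`: 17000 nM
compound 3, `ClCc1ccccc1Cn1cnc2ncnc(Cl)c21`: 20400 nM

Compound 1 and compound 3 have the same atoms joined differently; the difference between the two cores is not broken down here. Compound 3 stands at the highest of the three numbers in this assay, yet against compound 2 the gap is within the scatter, so no order between those two is claimed. Against compound 1 the gap is beyond the scatter.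

Within the core of compound 1, compound 2 carries the change chloro in place of hydrogen on an aromatic carbon and gives a 2.0-fold higher number from compound 1 to compound 2 (0.29 log units; within the scatter). The same kind of change, (chloro in place of hydrogen on an aromatic carbon), carried on the core of compound 3 gives compound 4, `ClCc1ccccc1Cn1cnc2nc(Cl)nc(Cl)c21`, which is not yet measured in this assay. The two place descriptions agree word for word, so the surroundings of the change are the same in both cores.

For compound 4 the expected step in this assay is a 2.0-fold higher number from compound 3 to compound 4 (0.29 log units; within the scatter), set beside the earlier one because the measured pair gave a 2.0-fold higher number from compound 1 to compound 2 (0.29 log units; within the scatter) and nothing in the data suggests a different response on the core of compound 3. A single measured pair is a thin basis, so the range is kept wide. Compound 4 is therefore estimated at 40000 nM, expected to lie between 15000 nM and 100000 nM.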

Compound 4, concentration for total growth inhibition: 35500 nM
Beside the measured number, compound 4's estimate is 1.1-fold (0.05 log units) above it; the measured number falls inside the stated range.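

In this assay, chloro in place of hydrogen on an aromatic carbon, here between two ring nitrogen atoms, gives a 1.7-fold higher number from compound 3 to compound 4 (0.24 log units; within the scatter) and matches the step already seen on the other core: the same change on two cores in this assay, a 2.0-fold higher number (0.29 log units; within the scatter) from compound 1 to compound 2 and a 1.7-fold higher number (0.24 log units; within the scatter) from compound 3 to compound 4, 1.1-fold (0.05 log units) apart, within the scatter of two such steps. On these two pairs, then, the step read on one core served as a fair guide to the step on the other, and nothing points to a different response between the two cores. This does not show that the chloro group itself shifts growth inhibition, as each step taken alone lies within the scatter, and two pairs with a single change in a single cell line do not make a rule for the series.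

The compounds shown carry only hydrogen or chloro at this place, so it remains open whether an amine, a methoxy group or a thiol there would behave alike on both cores. Also open, as far as these compounds go, is how the series responds when the chloromethyl group gives way to a hydroxymethyl group or a longer chain, and whether the agreement between cores would hold for such changes.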